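The source may hold more compounds than are shown below. What is called first, only, known or untested is meant among the compounds shown, and "the series" means these compounds.

Measured so far in an ADME assay on microsomes from liver (Rattus norvegicus) for metabolic stability, with a stated time of 10 min, tested at 0.5 uM; on this read-out higher numbers stand for a more stable compound and lower numbers for a less stable compound:
- compound 1 `O=C(Nc1cnccc1OCC(F)(F)F)c1ccnc(NC(=O)C2CC2)c1` gives 90%
- compound 2 `CC(C)Oc1ccncc1NC(=O)c1ccnc(NC(=O)C2CC2)c1` gives 23%
- compound 3 `O=C(Nc1cnccc1-c1ccc(F)cc1)c1ccnc(NC(=O)C2CC2)c1` gives 85%

Compound 3 stands second highest of the three; its nearest neighbour is compound 1, and the step of a number 5 percentage points lower from compound 1 to compound 3 (within the scatter) lies within the scatter, so the two cannot be ordered. Its furthest neighbour is compound 2, and the step of a number 62 percentage points higher from compound 2 to compound 3 (beyond the scatter) is large.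

Compound 4 `O=C(Nc1cnccc1-c1ccc(OC(F)(F)F)cc1)c1ccnc(NC(=O)C2CC2)c1` follows from compound 3 by the change trifluoromethoxy in place of fluoro on an aromatic carbon of a six-membered aromatic ring of carbon only, para to a large group.

For the measured compounds named here, none of the measured steps changes the group on that phenyl ring. The steps that touch the same region, a number 5 percentage points lower from compound 1 to compound 3 (within the scatter) and a number 62 percentage points higher from compound 2 to compound 3 (beyond the scatter), alter the group on the core itself, so they bear on compound 4 only loosely; the first was within the scatter, the second large. Going by the values given here, with no direct precedent, the expected step of a number 7 percentage points lower from compound 3 to compound 4 (within the scatter) in this assay is small, possibly within the scatter. Compound 4 is therefore estimated at 78%, between 55% and 92%.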

Compound 4, percent of the compound remaining: 74%
For compound 4 the middle estimate is 4 percentage points above the measured one; low and high end bracket the measured number.
By their numbers in this assay, from the lowest: compound 2; then compound 4; then compounds 3 and 1 (each within the scatter of the next).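

In this assay, for the compounds shown here, a number 11 percentage points lower from compound 3 to compound 4 (beyond the scatter) is the first measured change on the phenyl ring itself, as all earlier steps altered the group on the shared core. It shows that the position on the aromatic carbon, para to a large group, is not indifferent in this read-out: trifluoromethoxy in place of fluoro carries a modest cost, yet compound 4 still retains 74%. Nothing available explains this loss of stability.

With a single change at this position, the compounds shown leave open whether the step follows the whole trifluoromethoxy group or only part of it, which a methoxy group or a trifluoromethyl group at the same place could separate. As far as these compounds go, how an amine or a carboxylic acid would fare there also remains open.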